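This account rests on a few compounds, and the source may have more. Where it says the series, first, only, none or still open, it means among the compounds named here.

Measured compounds in the series:
compound 1 `Cn1c(=O)c(=O)n(C2CCCC2)c2nc(N/N=C/c3ccc(S(C)(=O)=O)cc3)ncc21`, 26600 nM
compound 2 `Cn1c(=O)c(=O)n(C2CCCC2)c2nc(N/N=C/c3ccc(O)c(F)c3)ncc21`, 85200 nM

Compound 2 gives the highest of the two numbers in a functional assay on PC-3 cells (Homo sapiens) for antiproliferative activity, read by MTT assay; a lower number here means a stronger inhibitor, a higher number a weaker inhibitor; the nearest is compound 1, a step of a 3.2-fold higher number from compound 1 to compound 2 (0.51 log units; beyond the scatter) separating them. Compound 3 `Cc1ccc(/C=N/Nc2ncc3c(n2)n(C2CCCC2)c(=O)c(=O)n3C)cc1C` differs from compound 2 by 3,4-dimethylphenyl in place of 3-fluoro-4-hydroxyphenyl on a carbon with a double bond to nitrogen. For the measured compounds named here, no measured step touches this change: the one recorded step, from compound 1 to compound 2, exchanges 4-(methylsulfonyl)phenyl for 3-fluoro-4-hydroxyphenyl on the same carbon and says only that the fluoro-hydroxy ring sits at the weak end of the pair. What 3,4-dimethylphenyl does at this position cannot be read from the data; a step of modest size in either direction, or none beyond the scatter, is equally possible. Compound 3 is therefore expected near compound 2, the estimated step being a 1.4-fold lower number from compound 2 to compound 3 (0.15 log units; within the scatter), giving an estimate of 60000 nM with a range from 15000 nM to 200000 nM.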

Compound 3, half-maximal inhibitory concentration: 39000 nM
Compound 3: middle estimate off by 1.5-fold (0.19 log units), on the high side; low and high end bracket the measured number.
By their numbers in this assay, from the lowest: compounds 1 and 3 (each within the scatter of the next); then compound 2.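

In this assay the ring on the carbon with a double bond to nitrogen still matters when the exchange is 3-fluoro-4-hydroxyphenyl for 3,4-dimethylphenyl, which gives a 2.2-fold lower number from compound 2 to compound 3 (0.34 log units; beyond the scatter) and removes the hydrogen-bond donor and acceptor of the leaving ring. Exchanging 4-(methylsulfonyl)phenyl for 3,4-dimethylphenyl gives a 1.5-fold higher number from compound 1 to compound 3 (0.17 log units; within the scatter), so these two rings cannot be told apart at this position, and only 3-fluoro-4-hydroxyphenyl stands apart from both. No supporting data are available to explain these differences.

The compounds shown do not separate the contribution of the hydroxy group from that of the fluorine in 3-fluoro-4-hydroxyphenyl. As far as these compounds go, how an amine, a carboxylic acid or an unsubstituted phenyl ring would behave on this carbon also remains open.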